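The compounds below may be only part of what the source reports. "The series", "measured", "known", "first", "only" and "open" are said of these compounds alone.

Working notes on the series, read in a functional assay on MGC-803 cells (Homo sapiens) for inhibition, read by MTT assay, with a stated time of 72 h; a lower number here means a stronger inhibitor, a higher number a weaker inhibitor. Compound 1 (`Cc1ccc(NC(=O)C2CCN(C/C=C/c3ccccc3)CC2)cc1`) gives 24100 nM and compound 2 (`COc1cccc(NC(=O)C2CCN(C/C=C/c3ccccc3)CC2)c1`) gives 37200 nM. The step between them is a 1.5-fold higher number from compound 1 to compound 2 (0.19 log units; within the scatter). Compound 3 (`O=C(Nc1cccc(Cl)c1)C1CCN(C/C=C/c2ccccc2)CC1`) gives 11300 nM, the lowest number of the three. It is reached by a 2.1-fold lower number from compound 1 to compound 3 (0.33 log units; beyond the scatter) and by a 3.3-fold lower number from compound 2 to compound 3 (0.52 log units; beyond the scatter), and both steps are modest.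

The next structure is compound 4 (`O=C(Nc1cccc(Br)c1)C1CCN(C/C=C/c2ccccc2)CC1`), which carries bromo in place of chloro on an aromatic carbon, meta to a large group: bromo in place of chloro on an aromatic carbon. Among the measured compounds shown here, no measured step exchanges one halogen for another, so the evidence is indirect. For the measured compounds named here, the closest precedent is the exchange of methoxy for chloro that leads to compound 3, a 3.3-fold lower number from compound 2 to compound 3 (0.52 log units; beyond the scatter). That step replaces a different kind of group, so it sets only a loose upper guide to the size of a change here. The step from the 4-methylphenyl of compound 1, a 2.1-fold lower number from compound 1 to compound 3 (0.33 log units; beyond the scatter), bears less, since it changes more than one feature of that ring.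

No step beyond the scatter is expected in this assay, and no direction is favoured. For compound 4 the expected value is 10000 nM. The estimated range for compound 4 runs from 5000 nM to 20000 nM. This estimate means an expected 1.1-fold lower number from compound 3 to compound 4 (0.05 log units; within the scatter).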

Compound 4, half-maximal inhibitory concentration: 9110 nM
The estimate for compound 4 lay 1.1-fold (0.04 log units) above the measured number; low and high end bracket the measured number.
By their numbers in this assay, from the lowest: compounds 4 and 3 (each within the scatter of the next); then compounds 1 and 2 (each within the scatter of the next).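

In this assay, among the compounds shown here, this is the first exchange of one halogen for another on an aromatic carbon meta to a large group, and a 1.2-fold lower number from compound 3 to compound 4 (0.09 log units; within the scatter) leaves chloro and bromo unseparated at this place. The lower numbers of compound 3 therefore do not depend on chloro alone: bromo also stands clear of the other aryl groups, with (a 4.1-fold lower number from compound 2 to compound 4 (0.61 log units; beyond the scatter)) against the 3-methoxyphenyl compound and (a 2.6-fold lower number from compound 1 to compound 4 (0.42 log units; beyond the scatter)) against the 4-methylphenyl compound, both steps modest. No measurement at hand accounts for the close agreement of the two halogens or for these modest gaps.

The compounds shown do not tell how fluoro, iodo, trifluoromethyl or an amine would read at the same place, so it remains open whether the level shared by compound 3 and compound 4 extends beyond chloro and bromo. All four compounds also keep the rest of the core of compound 1 unchanged, which leaves open how far a carboxylic acid or a longer chain elsewhere on that core would move the number.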